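This account rests on a few compounds, and the source may have more. Where it says the series, first, only, none or still open, it means among the compounds named here.

Compound 1 `CC(C)c1onc(-c2c(Cl)cccc2Cl)c1COc1ccc(-c2nc3ccc(C(=O)O)cc3n2CC(C)(C)C)cc1` was tested in an assay on Huh-7 cells for agonist activity at Bile acid receptor (Homo sapiens), read by a luciferase reporter (on this read-out lower numbers stand for an effect already at smaller amounts and higher numbers for an effect only at larger amounts of compound), where compound 1 gives 13 nM. Of the two compounds measured there, compound 1 stands at the higher number; compound 2 `CC(C)c1onc(-c2c(Cl)cccc2Cl)c1COc1ccc(-c2nc3ccc(C(=O)O)cc3n2C)c(Cl)c1` gives 3.66 nM in this assay, and the gap between the two lies beyond the usual scatter. The pair differs at more than one place, so nothing is drawn from it beyond the two numbers themselves. Compound 3 `CC(C)c1onc(-c2c(Cl)cccc2Cl)c1COc1ccc(-c2nc3ccc(C(=O)O)cc3n2C2CCCC2)cc1` has not yet been measured. Set against compound 1 it shows a single change: cyclopentyl in place of neopentyl on an aromatic nitrogen. Within the data shown here, no measured step isolates this swap, so its effect can only be expected. The expectation is for no step beyond the scatter, and the step is estimated as a 1.3-fold lower number from compound 1 to compound 3 (0.11 log units; within the scatter). Compound 3 is therefore expected to give about 10 nM in this assay, in a range from 3.5 nM to 30 nM.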

Compound 3, half-maximal effective concentration: 13.6 nM
Compound 3: middle estimate off by 1.4-fold (0.13 log units), on the low side; the measured number falls inside the stated range.
By their numbers in this assay, from the lowest: compound 2; then compounds 1 and 3 (each within the scatter of the next).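

This comparison isolates the group on the aromatic nitrogen: cyclopentyl in place of neopentyl gives a 1.0-fold higher number from compound 1 to compound 3 (0.02 log units; within the scatter) in this assay. At this position, then, a five-membered carbon ring and an open group with no ring, each of 5 carbon atoms, cannot be told apart on this read-out. Nothing available explains why the two groups read alike.

Both groups hold only carbon and have no hydrogen-bond donors or acceptors, so how a chain ending in an amine or a hydroxyl would read at this nitrogen remains an open question. Also open, as far as these compounds go, are a phenyl ring or a longer chain in the same place, and whether the match between neopentyl and cyclopentyl would hold on a different core.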